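From methoxycarbonyl to carboxy in compound 3

The source may hold more compounds than are shown below. What is called first, only, known or untested is meant among the compounds shown, and "the series" means these compounds.

Compound 1 `C[C@H](NC(=O)/C=C/c1ccc(O)c2oc(-c3ccc(O)c(O)c3)cc12)C(=O)O`: 3270 nM
Compound 2 `COC(=O)[C@H](C)NC(=O)/C=C/c1ccc(OC)c2oc(-c3ccc(O)c(O)c3)cc12`: > 100000 nM

Both compounds were tested in a functional assay, read by spectrophotometry, with a stated time of 30 min; on this read-out higher numbers stand for weaker inhibition and lower numbers for stronger inhibition. Compound 2 reads > 100000 nM, and this is a limit of the assay, not a number. Compound 2 therefore stands at the limit of > 100000 nM in this assay, at which 1 of the 2 values shown sits. Compound 1, which carries a carboxy group, gives a true number, 3270 nM.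

Compound 3 `COc1ccc(/C=C/C(=O)N[C@@H](C)C(=O)O)c2cc(-c3ccc(O)c(O)c3)oc12` differs from compound 2 in one place: hydrogen in place of methyl on an oxygen next to a carbonyl group. Hydrogen takes the place of methyl on an oxygen next to a carbonyl group, so methoxycarbonyl becomes carboxy.

Going by the values given here, no pair of measured compounds shows this change alone, and the limit for compound 2 leaves the size of any step open. Compound 3 would share the carboxy group of compound 1, which gives 3270 nM, so a step beyond the scatter towards stronger inhibition is expected in this assay. The expected change is an at least 6.6-fold lower number from compound 2 to compound 3 (0.82 log units; beyond the scatter). For compound 3 the estimated value is 15000 nM, with an expected range of 3000 nM to 80000 nM.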

Compound 3, half-maximal inhibitory concentration: > 100000 nM
Compound 3 was reported as a limit; the forecaster's own chance of this, stated with the estimate: 15%; middle value at least 6.6-fold (0.82 log units) away from the limit.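

In this assay compound 3 reads > 100000 nM, which is a limit of the assay and not a number. Changing methoxycarbonyl to carboxy therefore does not bring this compound back to a readable value, and the step from compound 2 to compound 3 cannot be read, as both ends are limits; the two compounds share the same ceiling: the limit of > 100000 nM in this assay, at which 2 of the 3 values shown sit.

The informative comparison is now with compound 1, which also carries the carboxy group: with methyl in place of hydrogen on an oxygen on an aromatic ring, the data show an at least 30-fold higher number from compound 1 to compound 3 (1.48 log units; beyond the scatter), which means weaker inhibition. So the carboxy group alone is not enough for a readable value in this pair, and this one change on the aromatic oxygen is enough to lose it.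

Going by these compounds, whether changing carboxy to methoxycarbonyl would also weaken inhibition when that aromatic oxygen carries hydrogen stays open, as the limits hide any effect of this change. Also open, on these data alone, is what an ethyl group or a longer chain on that oxygen, or an amine in place of the carboxy group, would do to the number.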